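The source may hold more compounds than are shown below. What is called first, only, known or untested is meant among the compounds shown, and "the series" means these compounds.

Measured compounds:
Compound 1 `Cn1cncc1CN1CC(N(CC2CCN(C(=O)c3ccc(Cl)cc3)CC2)S(=O)(=O)c2ccccn2)Cc2cc(C#N)ccc21` gives 0.5 10^-6 cm/s in an ADME assay on Caco-2 cells (Homo sapiens) for permeability, in the apical to basolateral direction; a higher number here means that the compound crosses the layer faster, a lower number that the compound crosses the layer more slowly.
Compound 2 `CC(C)NC(=O)N1CCC(CN(C2Cc3cc(C#N)ccc3N(Cc3cncn3C)C2)S(=O)(=O)c2ccccn2)CC1` gives 0.6 10^-6 cm/s in this assay.
Compound 3 `Cn1cncc1CN1CC(N(CC2CCN(C(=O)c3cccs3)CC2)S(=O)(=O)c2ccccn2)Cc2cc(C#N)ccc21` gives 0.5 10^-6 cm/s in this assay.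

Compound 2 has the highest of the three numbers, but its nearest neighbour is compound 1 with a 1.2-fold higher number from compound 1 to compound 2 (0.08 log units; within the scatter) and the furthest is compound 3 with a 1.2-fold lower number from compound 2 to compound 3 (0.08 log units; within the scatter), so the three compounds sit together in this assay and no order among them can be claimed. The step from compound 1 to compound 3, no change at the digits printed from compound 1 to compound 3 (within the scatter), likewise shows nothing beyond the scatter.

Compound 4 `Cn1cncc1CN1CC(N(Cc2ccc(S(C)(=O)=O)cc2)S(=O)(=O)c2ccccn2)Cc2cc(C#N)ccc21` has not been measured. The change from compound 2 is 4-(methylsulfonyl)phenyl in place of 1-(isopropylcarbamoyl)piperidin-4-yl on a saturated chain carbon bound to a sulfonamide nitrogen. None of the three measured steps bears directly on it: each of them alters only the group on the carbonyl carbon, and each stayed within the scatter. The data therefore give no guidance on the size of the step in this assay, and compound 4 is expected to land close to the measured compounds, with a 1.7-fold higher number from compound 2 to compound 4 (0.22 log units; within the scatter) as the estimated step. Compound 4 is estimated at 1 10^-6 cm/s, with a range from 0.3 10^-6 cm/s to 3 10^-6 cm/s.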

Compound 4, apparent permeability: 0.2 10^-6 cm/s
Compound 4: middle estimate off by 5.0-fold (0.70 log units), on the high side; the measured number lies below the stated range.
By their numbers in this assay, from the lowest: compound 4; then compounds 1, 3 and 2 (each within the scatter of the next).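

In this assay, among these compounds, the group on the saturated chain carbon bound to a sulfonamide nitrogen moves the number, with a 3.0-fold lower number from compound 2 to compound 4 (0.48 log units; beyond the scatter), whereas the changes on the carbonyl carbon among the earlier compounds all stayed within the scatter. This step exchanges a six-membered non-aromatic ring with 1 hydrogen-bond donor for a six-membered aromatic ring of carbon only with 0 hydrogen-bond donors, so several features change together and this one step cannot separate them. No measurement shown here accounts for the lower number.

As far as these compounds go, it remains open whether the ring, the methylsulfonyl group or the loss of the isopropylcarbamoyl group matters most. A plain phenyl, or a 4-aminophenyl, at this place would begin to separate these features.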